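A chloro added beside the trifluoromethyl in the diarylurea tail

A few compounds are considered here, and "the series" means these few. Any claim that something is new, unique, unknown or untested is made for them only; others in the source may bear on it.

Compound 1 `O=C(Nc1cccc(-n2cc(-c3ccncc3)c(-c3ccc(Cl)c(O)c3)n2)c1)Nc1cccc(C(F)(F)F)c1` carries a urea that joins the shared core to a 3-(trifluoromethyl)phenyl group. In a functional assay on NCI-H23 cells (Homo sapiens) for inhibition, read by sulforhodamine B assay, with a stated time of 48 h (on this read-out lower numbers stand for higher toxicity in this test and higher numbers for lower toxicity in this test), compound 1 gives only a limit, > 32500 nM, and not a measured number. Its one close relative, compound 2 `O=C(Nc1cccc(-n2cc(-c3ccncc3)c(-c3ccc(Cl)c(O)c3)n2)c1)Nc1cc(C(F)(F)F)cc(C(F)(F)F)c1`, places a second trifluoromethyl on that phenyl and in this assay gives 18200 nM. The step of an at least 1.7-fold lower number from compound 1 to compound 2 (0.25 log units; that floor lies within the scatter) is therefore one that at least reaches the edge of the scatter. That step starts from the limit of compound 1 (the limit of > 32500 nM in this assay, at which 1 of the 2 values shown sits). Compound 3 `O=C(Nc1cccc(-n2cc(-c3ccncc3)c(-c3ccc(Cl)c(O)c3)n2)c1)Nc1ccc(Cl)c(C(F)(F)F)c1` is the companion that has not yet been tested: it differs from compound 1 by chloro in place of hydrogen on an aromatic carbon, so that the tail becomes 4-chloro-3-(trifluoromethyl)phenyl. For the measured compounds named here, the only step that bears on this change is the one from compound 1 to compound 2, a small added group on the same ring, and it moved the number modestly downward. A step of similar size is expected here, an at least 1.6-fold lower number from compound 1 to compound 3 (0.21 log units; that floor lies within the scatter), though a reading that again ends at the limit cannot be ruled out. Compound 3 is estimated at 20000 nM, with a plausible range from 8000 nM to 45000 nM.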

Compound 3, concentration lethal to 50% of the cells: 26100 nM
Estimate against measurement, compound 3: 1.3-fold (0.12 log units) below; measured number inside the range.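

In this assay, putting chloro in place of hydrogen on the 3-(trifluoromethyl)phenyl tail gives an at least 1.2-fold lower number from compound 1 to compound 3 (0.09 log units; that floor lies within the scatter), so this floor alone does not establish a real change in the number. What compound 3 adds is a measured value for a tail that carries a substituent at this position, ortho to a trifluoromethyl group and para to a large group, and it is the only compound shown with chloro there. Compound 1 stands at a limit and not at a measured number, so the true size of the step stays unknown and only its floor can be read: the limit of > 32500 nM in this assay, at which 1 of the 3 values shown sits.

The compounds shown do not settle whether the gap in this assay is really larger than that floor, or whether this position responds to the kind of group placed on it. A fluoro, a bromo, a methoxy group, an amine or a carboxylic acid at the same position would each test this, and none of them is among the compounds shown here.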